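A few compounds are considered here, and "the series" means these few. Any claim that something is new, unique, unknown or untested is made for them only; others in the source may bear on it.

Compound 2 `C=C(Br)C(=O)Nc1cccc(-c2cn3nc(Cc4cccc(OC)c4)sc3n2)c1` gives 1100 nM in a functional assay on FM3A cells (Mus musculus) for inhibition, read by cell counting, with a stated time of 2 days (a higher number here means a weaker inhibitor, a lower number a stronger inhibitor), the lowest of the three numbers reported so far. Compound 3 `COc1cccc(Cc2nn3cc(-c4cccc(N)c4)nc3s2)c1` gives 10000 nM, and compound 1 `COc1cccc(-c2nn3cc(-c4cccc(N)c4)nc3s2)c1` gives 29000 nM. Among the measured compounds shown here, the only step recorded between measured compounds is a 9.1-fold higher number from compound 2 to compound 3 (0.96 log units; beyond the scatter), where hydrogen takes the place of (1-bromoethenyl)carbonyl on a nitrogen on an aromatic ring.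

Compound 4 `C=C(Br)C(=O)Nc1cccc(-c2cn3nc(-c4ccccc4)sc3n2)c1` keeps that acyl group and alters the other side of the shared core: phenyl in place of 3-methoxybenzyl on an aromatic carbon. For the measured compounds named here, no measured step follows this exact change, so the recorded step from compound 2 to compound 3 does not bear on it directly. What compounds 1 and 3 show is only that, with the free amine shared and the group on the five-membered ring differing, compound 1 gives 29000 nM while compound 3 gives 10000 nM in this assay, a gap that is beyond the scatter. On that thin evidence, with the acyl group retained, compound 4 is expected to stay nearer compound 2 than compound 1, with a modest move toward a higher number, a 2.3-fold higher number from compound 2 to compound 4 (0.36 log units; beyond the scatter). Compound 4 is therefore estimated at 2500 nM, within a range from 600 nM to 10000 nM.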

Compound 4, half-maximal inhibitory concentration: 900 nM
The estimate for compound 4 lay 2.8-fold (0.44 log units) above the measured number; the range from low to high includes it.
By their numbers in this assay, from the lowest: compounds 4 and 2 (each within the scatter of the next); then compound 3; then compound 1.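

With the (1-bromoethenyl)carbonyl group kept on the nitrogen, placing phenyl instead of 3-methoxybenzyl on this aromatic carbon gives a 1.2-fold lower number from compound 2 to compound 4 (0.09 log units; within the scatter) in this assay, so the two compounds cannot be told apart in this read-out. This is the first pair shown that differs only at this position, whereas the one earlier step concerned the acyl group on the nitrogen. Here, neither the loss of the methoxy oxygen nor the move from 3-methoxybenzyl to the smaller count of heavy atoms in phenyl shifts the number beyond the scatter, and no measurement shown explains this outcome.

The compounds shown leave open how an amine, a carboxylic acid or a longer chain on this aromatic carbon would read in this assay, and whether an unsubstituted benzyl group would also stay within the scatter of these two compounds. They also leave open whether a chloroacetyl group on the nitrogen could stand in for the (1-bromoethenyl)carbonyl group while phenyl stays in place.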